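Replacing the Fluorophenyl on the Ring Nitrogen

The source may report more compounds than this note shows. Statements on the series, on what has been measured and on what is new or still open speak of the compounds shown alone.

Of the compounds shown here, two have been measured in an assay on isolated protein for inhibition of protein kinase C zeta type (Homo sapiens), with a stated time of 4 min, tested at 62.5 uM; on this read-out lower numbers stand for less inhibition and higher numbers for more inhibition at the one concentration tested (going by the name of the read-out). Compound 1 `CC(C)c1ccc(N2N=C(C(C)(C)C)CC2c2ccc(O)cc2)cc1` gives 54.9% in this assay. Compound 2 `CC(C)(C)C1=NN(c2cccc(F)c2)C(c2ccc(O)cc2)C1` gives 98.1% in this assay, the higher of the two numbers, and its gap to compound 1 lies beyond the scatter. Compound 3 `Cc1ccc(N2N=C(C(C)(C)C)CC2c2ccc(O)cc2)c(C)c1` has not yet been measured. It differs from compound 2 in one place: 2,4-dimethylphenyl in place of 3-fluorophenyl on an amine nitrogen in a ring. Within the data shown here, no measured pair isolates this change, so the two values shown are the only guide. Compound 1 also lacks fluorine in the group on the amine nitrogen in a ring and stands at 54.9%, well under compound 2. A downward step from compound 2 to compound 3, a number 23.1 percentage points lower from compound 2 to compound 3 (beyond the scatter), is therefore expected, of moderate size. Compound 3 is estimated to give 75% in this assay, with a range from 50% to 95%.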

Compound 3, a percentage reported as inhibition, at one concentration (the size of the read-out at that concentration, not a potency): 59.9%
Compound 3: the middle estimate sits 15.1 percentage points above what was measured, and the stated range covers the measured number.
By their numbers in this assay, from the lowest: compounds 1 and 3 (each within the scatter of the next); then compound 2.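

Placing 2,4-dimethylphenyl in place of 3-fluorophenyl on the amine nitrogen in a ring gives, in this assay, a number 38.2 percentage points lower from compound 2 to compound 3 (beyond the scatter) and so isolates a change at this position for the first time. Compound 1 gives 54.9% and compound 3 gives 59.9% in this assay; these values lie within the scatter of each other, so two different fluorine-free groups at this position give matching results, and only compound 2 stands apart. Nothing measured here explains the step.

The compounds shown leave open whether the high value of compound 2 depends on fluorine itself or on where the substituent sits, as a plain phenyl, a 4-fluorophenyl, a 3-chlorophenyl or a 3-methylphenyl group on this nitrogen could show. On these data alone, each number also comes from a single concentration, so how the three compounds compare in potency remains open.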